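Aminothiazole series: dipropylamino replacement for the piperazine

A few compounds are considered here, and "the series" means these few. Any claim that something is new, unique, unknown or untested is made for them only; others in the source may bear on it.

Measured compounds:
compound 1 `CC(C)Cc1nc2cc(N(C)C3CCCCC3)c(Nc3nc(-c4ccccc4)cs3)cc2[nH]c1=O`, 33300 nM
compound 2 `CN1CCN(c2cc3ncc(=O)[nH]c3cc2Nc2nc(-c3ccccc3)cs2)CC1`, 10200 nM

In an ADME assay on Huh-7 cells (Homo sapiens) for cytotoxicity (a lower number here means a stronger inhibitor, a higher number a weaker inhibitor), compound 2 gives 10200 nM and so has the lower of the two numbers available; compound 1 gives 33300 nM, and the gap between these two values lies beyond the usual scatter. For the measured compounds named here, the two compounds differ at more than one place, so no single step is drawn between them and only their two values are compared.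

Compound 3 `CCCN(CCC)c1cc2ncc(=O)[nH]c2cc1Nc1nc(-c2ccccc2)cs1` is not yet measured. It is reached from compound 2 by dipropylamino in place of 4-methylpiperazin-1-yl on an aromatic carbon. Going by the values given here, the pair of measured compounds provides no step that maps onto this change, so the expectation for this assay rests on compound 2 alone. A change of a 1.3-fold lower number from compound 2 to compound 3 (0.11 log units; within the scatter) is expected, which keeps compound 3 within the scatter of compound 2 or slightly lower. Compound 3 is estimated at 8000 nM, with a range from 2500 nM to 25000 nM.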

Compound 3, half-maximal inhibitory concentration: 31600 nM
Estimate against measurement, compound 3: 4.0-fold (0.60 log units) below; measured number outside the range, above it.
By their numbers in this assay, from the lowest: compound 2; then compounds 3 and 1 (each within the scatter of the next).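

In this assay, for the compounds shown here, dipropylamino in place of 4-methylpiperazin-1-yl on this aromatic carbon gives a 3.1-fold higher number from compound 2 to compound 3 (0.49 log units; beyond the scatter) and provides the first single-place change that can be read. The step lies beyond the scatter, so the number at this position depends on the group carried there, even though both groups have the same heavy-atom count. Nothing available accounts for the step.

The compounds shown do not separate the loss of the ring from the loss of the second nitrogen, a question that piperidine or morpholine on the same aromatic carbon would address. From the compounds shown here alone, how diethylamino, with its shorter chains, would compare with dipropylamino also remains open.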